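Capping the hydroxy group of compound 3

The compounds below may be only part of what the source reports. "The series", "measured", "known", "first", "only" and "open" are said of these compounds alone.

Values in an ADME assay on HEK293 cells (Homo sapiens) for cytotoxicity, read by reporter gene assay and resazurin assay, with a stated time of 48 h; on this read-out lower numbers stand for higher toxicity in this test and higher numbers for lower toxicity in this test:
compound 1 `O=C(Nc1ccc(Sc2nc3ccccc3s2)c(Cl)c1)c1cccc(Br)c1O`: 64000 nM
compound 2 `COc1c(Br)cccc1C(=O)Nc1ccc(Sc2nc3ccccc3s2)c(Cl)c1`: > 100000 nM, which is a limit of the assay and not a number
compound 3 `O=C(Nc1ccc(Sc2nc3ccccc3s2)c(Cl)c1)c1cc(Br)ccc1O`: 45000 nM

Going by the values given here, compound 3, at 45000 nM, cannot be told apart from the only other compound with a true number, as the gap is a 1.4-fold lower number from compound 1 to compound 3 (0.15 log units; within the scatter). The next compound, compound 4 `COc1ccc(Br)cc1C(=O)Nc1ccc(Sc2nc3ccccc3s2)c(Cl)c1`, differs from compound 3 in one place: methyl in place of hydrogen on an oxygen on an aromatic ring. This is methyl in place of hydrogen on an oxygen on an aromatic ring, which turns 5-bromo-2-hydroxyphenyl into 5-bromo-2-methoxyphenyl.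

The same swap has been measured once, as an at least 1.5-fold higher number from compound 1 to compound 2 (0.19 log units; that floor lies within the scatter). Going by these compounds, compound 2 sits at the limit of > 100000 nM in this assay, at which 1 of the 3 values shown sits, so that step gives only a floor and its true size stays unknown. A second comparison, an at least 2.2-fold lower number from compound 2 to compound 3 (0.34 log units; beyond the scatter), points the same way, though it changes more than the methyl alone. With compound 2 as the main guide, a small to modest rise in this assay is expected, and the reading may reach the same limit. The expected value for compound 4 is 90000 nM, with an estimated range of 50000 nM to 170000 nM. The expected change is a 2.0-fold higher number from compound 3 to compound 4 (0.30 log units; within the scatter).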

Compound 4, half-maximal cytotoxic concentration: > 100000 nM
Compound 4 ended at the assay's limit (the forecaster's own chance of this, stated with the estimate: 50%); at least 1.1-fold (0.04 log units) between middle value and limit.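

In this assay, the step from hydroxy to methoxy on the 5-bromo-2-hydroxyphenyl group is now large enough to read, an at least 2.2-fold higher number from compound 3 to compound 4 (0.34 log units; beyond the scatter), whereas the earlier floor for this change lay within the scatter. The change thus raises the number in both pairs shown, with the bromine in either of its two places on the ring, although neither step has a known size: the same change on two cores in this assay, an at least 1.5-fold higher number (0.19 log units; that floor lies within the scatter) from compound 1 to compound 2 and an at least 2.2-fold higher number (0.34 log units; beyond the scatter) from compound 3 to compound 4; the limit leaves it open whether they differ. Going from the 3-bromo-2-hydroxyphenyl group to the 5-bromo-2-methoxyphenyl group gives an at least 1.5-fold higher number from compound 1 to compound 4 (0.19 log units; that floor lies within the scatter), while the step between compound 2 and compound 4 cannot be read, as both compounds rest on a limit rather than a number: the limit of > 100000 nM in this assay, at which 2 of the 4 values shown sit.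

Going by these compounds, how far methyl truly raises the number stays open, as does whether the two bromine placements respond equally. An ethyl or an acetyl group on the same oxygen would help show whether this rise is particular to methyl or also appears with other groups in place of the hydroxy hydrogen.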